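Hydrazone amides: fluorine-to-chlorine swap on the benzoyl arm

This account rests on a few compounds, and the source may have more. Where it says the series, first, only, none or still open, it means among the compounds named here.

Measured so far:
compound 1 `CC(/C=N/Nc1ccc([N+](=O)[O-])cc1)=N\NC(=O)c1ccccc1F` — > 100000 nM
compound 2 `CC(/C=N/N(C)c1ccc([N+](=O)[O-])cc1)=N\NC(=O)c1ccccc1O` — 31500 nM

In an ADME assay on J774 cells (Mus musculus, strain BALB/c) for cytotoxicity, read by resazurin assay, with a stated time of 72 h (a lower number here means that less compound is tolerated, a higher number that more compound is tolerated), compound 1 gives > 100000 nM, which is a limit of the assay and not a number. Compound 2 gives 31500 nM in this assay. Compound 1 therefore stands at the limit of > 100000 nM in this assay, at which 1 of the 2 values shown sits. Compound 3 `CC(/C=N/Nc1ccc([N+](=O)[O-])cc1)=N\NC(=O)c1ccc(Cl)cc1` is not yet measured; it differs from compound 1 by 4-chlorophenyl in place of 2-fluorophenyl on a carbonyl carbon. Within the data shown here, no measured step of this kind exists here, so the expected change is small, within the scatter, and compound 3 is estimated at 90000 nM (range 30000 nM to 300000 nM), an expected step of an at least 1.1-fold lower number from compound 1 to compound 3 (0.04 log units; that floor lies within the scatter).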

Compound 3, half-maximal cytotoxic concentration: 63900 nM
Estimate against measurement, compound 3: 1.4-fold (0.15 log units) above, and the stated range covers the measured number.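

In this assay, the swap on the carbonyl carbon reads as an at least 1.5-fold lower number from compound 1 to compound 3 (0.19 log units; that floor lies within the scatter). Only this floor is known, and it does not separate 4-chlorophenyl from 2-fluorophenyl at this position, though compound 3 gives a real number on this arm. Compound 1 stands at a limit of the assay and not at a number: the limit of > 100000 nM in this assay, at which 1 of the 3 values shown sits.

From the compounds shown here alone, the halogen and its place on the ring change together here, so their separate shares stay open. Also open, going by these compounds, is how an amine or a carboxylic acid on the benzoyl arm would read in this assay.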